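Methoxy removal on the pyrazole aryl: compound 4

The source may report more compounds than this note shows. Statements on the series, on what has been measured and on what is new or still open speak of the compounds shown alone.

Measured so far in a functional assay on A549 cells (Homo sapiens) for antiproliferative activity, read by MTT assay, with a stated time of 48 h; on this read-out lower numbers stand for stronger inhibition and higher numbers for weaker inhibition:
compound 1 `O=[N+]([O-])c1ccc(-c2nn(-c3ccccc3)cc2C(Nc2nc3ccccc3s2)c2c(O)ccc3ccccc23)cc1`: 41300 nM
compound 2 `COc1ccc2nc(NC(c3cn(-c4ccccc4)nc3-c3ccc([N+](=O)[O-])cc3)c3c(O)ccc4ccccc34)sc2c1`: 22500 nM
compound 3 `COc1cccc(-c2nn(-c3ccccc3)cc2C(Nc2nc3ccc(OC)cc3s2)c2c(O)ccc3ccccc23)c1`: 88100 nM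

Compound 2 and compound 3 differ in the core aryl, (3-methoxyphenyl in place of 4-nitrophenyl on an aromatic carbon), and the step of a 3.9-fold higher number from compound 2 to compound 3 (0.59 log units; beyond the scatter). Compound 4 `COc1ccc2nc(NC(c3cn(-c4ccccc4)nc3-c3ccccc3)c3c(O)ccc4ccccc34)sc2c1` is to be measured in this assay. It differs from compound 3 by hydrogen in place of methoxy on an aromatic carbon. The same kind of change, (hydrogen in place of methoxy on an aromatic carbon), has been measured once: a 1.8-fold higher number from compound 2 to compound 1 (0.26 log units; within the scatter). The place is not the same: there the methoxy sat on a ring that is part of a fused system of two rings, meta and para to a fused ring; here it sits meta to a large group on a plain phenyl ring. Within the data shown here, with only one prior step of this kind, and that within the scatter, a comparably small step is expected, a 1.2-fold higher number from compound 3 to compound 4 (0.10 log units; within the scatter). Compound 4 is thus estimated at 110000 nM, expected between 50000 nM and 250000 nM.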

Compound 4, half-maximal inhibitory concentration: 44600 nM
The estimate for compound 4 lay 2.5-fold (0.39 log units) above the measured number; measured number below the stated range.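

In this assay, replacing methoxy with hydrogen does not transfer as one fixed step from core to core: the same change on two cores in this assay, a 1.8-fold higher number (0.26 log units; within the scatter) from compound 2 to compound 1 and a 2.0-fold lower number (0.30 log units; within the scatter) from compound 3 to compound 4, 3.6-fold (0.56 log units) apart, beyond the scatter of two such steps. Read singly, a 2.0-fold lower number from compound 3 to compound 4 (0.30 log units; within the scatter) stays within the scatter, so the difference rests on the gap between two steps, and the two pairs also differ in where the methoxy sits. Among these compounds, with only two pairs, this does not show how the change would behave on a further core, and a 2.0-fold higher number from compound 2 to compound 4 (0.30 log units; within the scatter) for hydrogen in place of nitro is likewise a single step within the scatter.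

Still open, as far as these compounds go, is whether an amine or a carboxylic acid on that phenyl ring would give a step beyond the scatter.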